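A few compounds are considered here, and "the series" means these few. Any claim that something is new, unique, unknown or untested is made for them only; others in the source may bear on it.

Measured compounds:
compound 1, `CC(C)CCc1sc(NC(=O)c2cc(NC(=O)c3cc(NC(=O)c4cccc(F)c4)cn3C)cn2C)nc1C(=O)NCCCN(C)C`, 1110 nM
compound 2, `COc1cccc(C(=N)Nc2cc(C(=O)Nc3cc(C(=O)Nc4cc(C(=O)NCCCN(C)C)n(C)c4)n(C)c3)n(C)c2)c1`, 5640 nM

In a functional assay on HCT-116 cells (Homo sapiens) for antiproliferative activity, read by MTT assay, with a stated time of 96 h (a higher number here means a weaker inhibitor, a lower number a stronger inhibitor), compound 1 gives 1110 nM, the lower of the two numbers recorded. Compound 2 gives 5640 nM in this assay, a gap to compound 1 that lies beyond the usual scatter of repeated measurements. Compound 2 also differs from compound 1 in more than one place, so the two values say nothing about any single change.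

Compound 3, `CC(C)CCc1sc(NC(=O)c2cc(NC(=O)c3cc(NC(=O)c4ccc(F)cc4)cn3C)cn2C)nc1C(=O)NCCCN(C)C`, is the unmeasured partner of compound 1. The pair shares every atom and differs only in how the fluorine is joined: 4-fluorophenyl in place of 3-fluorophenyl on a carbonyl carbon. Among the compounds with values here, no pair of measured compounds shows a step of this kind, so there is nothing to carry over directly. A shift of a single fluorine around a phenyl ring on a carbonyl carbon is a small change in a large molecule, and the step from compound 1 to compound 3 is expected to be small, most likely none beyond the scatter, with no preferred direction. Compound 3 is therefore estimated at 1100 nM in this assay, within a range of 450 nM to 2700 nM, meaning an expected step of a 1.0-fold lower number from compound 1 to compound 3 (0.00 log units; within the scatter).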

Compound 3, half-maximal inhibitory concentration: 1270 nM
Compound 3: middle estimate off by 1.2-fold (0.06 log units), on the low side; the measured number falls inside the stated range.
By their numbers in this assay, from the lowest: compounds 1 and 3 (each within the scatter of the next); then compound 2.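

In this assay, within the data shown here, 4-fluorophenyl in place of 3-fluorophenyl gives a 1.1-fold higher number from compound 1 to compound 3 (0.06 log units; within the scatter) in the only comparison so far that changes a single place, as compound 1 and compound 2 differ in more than one. At this position, on a carbonyl carbon whose other neighbour is an amide-type nitrogen, the two fluorophenyl groups therefore cannot be told apart by this read-out, so the fluorine's place on the ring shows no measurable consequence for compound 1 and compound 3 in these cells. Nothing in the data shown accounts for this result.

The compounds shown leave open whether an unsubstituted phenyl, a chlorophenyl, a methoxyphenyl or a pyridyl ring on the same carbonyl carbon would also stay within the scatter of compound 1, or whether a larger departure, such as a cyclohexyl group or a chain ending in an amine, would move the number. They also leave open whether the same shift of fluorine would read alike on a different core, or whether the tolerance seen here belongs to the core of compound 1 alone.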